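The compounds below may be only part of what the source reports. "The series", "measured", "known", "first", "only" and "open" are said of these compounds alone.

Of the compounds shown here, three built on one shared core have so far been tested in an assay on isolated protein for inhibition of Polyunsaturated fatty acid 5-lipoxygenase (Homo sapiens), read by immunoassay, with a stated time of 15 min; on this read-out higher numbers stand for weaker inhibition and lower numbers for stronger inhibition. Compound 1 `NS(=O)(=O)c1ccc2c(c1)S(=O)(=O)N=S2c1ccc(Br)cc1` gives 91100 nM in this assay. Compound 2 `CCc1ccc(S2=NS(=O)(=O)c3cc([N+](=O)[O-])ccc32)cc1` gives 180 nM in this assay, the lowest of the three numbers. Compound 3 `COc1ccc(S2=NS(=O)(=O)c3cc([N+](=O)[O-])ccc32)cc1OC` gives 680 nM in this assay; its gap from compound 2 lies beyond the scatter, and the far larger gap from compound 1 to compound 2 does so as well.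

Compound 4 `O=[N+]([O-])c1ccc2c(c1)S(=O)(=O)N=S2c1ccc(C(F)(F)F)cc1` has not yet been measured. It differs from compound 2 in a single place: trifluoromethyl in place of ethyl on an aromatic carbon. Among the compounds with values here, no pair of measured compounds shows this exact change, so its size cannot be read off directly. Because compound 2 already gives 180 nM and the change brings no new donor, acceptor or charge, the step is expected to be small, a 1.7-fold higher number from compound 2 to compound 4 (0.22 log units; within the scatter), leaning slightly toward a weaker result and perhaps not beyond the scatter. Compound 4 is therefore expected to give about 300 nM in this assay, within a range from 80 nM to 1200 nM.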

Compound 4, half-maximal inhibitory concentration: 3090 nM
Beside the measured number, compound 4's estimate is 10-fold (1.01 log units) below it; measured number outside the range, above it.
By their numbers in this assay, from the lowest: compound 2; then compound 3; then compound 4; then compound 1.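

In this assay, this position, on an aromatic carbon para to a large group, proves highly sensitive: trifluoromethyl in place of ethyl produces a 17-fold higher number from compound 2 to compound 4 (1.23 log units; beyond the scatter). Within the data shown here, this is the first step here between measured compounds that differ in one place, and it shows that a large loss of inhibition can occur even when neither group carries a hydrogen-bond donor, a hydrogen-bond acceptor or a net charge. Nothing shown here explains why the number rises so far.

A single step cannot tell whether ethyl is especially favourable here or trifluoromethyl especially unfavourable, and a methyl group, a propyl chain or a chlorine atom at this place would help separate those two readings. As far as these compounds go, it also remains open whether the change would have a similar size on a core carrying something other than the nitro group.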